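A 4-phenylpiperazin-1-yl group replaces ethyl on the chain

The source may hold more compounds than are shown below. What is called first, only, known or untested is meant among the compounds shown, and "the series" means these compounds.

Measured in a functional assay on the whole organism with Mus musculus as the target, in the rotarod test; on this read-out higher numbers stand for an effect only at larger amounts of compound and lower numbers for an effect already at smaller amounts:
- compound 1 `CN(C(=O)CNC(=O)CN1CCCCC1)c1ccc(Cl)cc1C(=O)c1ccccc1Cl`: > 100 mg/kg, a limit of the assay and not a number
- compound 2 `CCC(=O)NCC(=O)N(C)c1ccc(Cl)cc1C(=O)c1ccccc1Cl`: 36 mg/kg
- compound 3 `CCCC(=O)NCC(=O)N(C)c1ccc(Cl)cc1C(=O)c1ccccc1Cl`: 55.2 mg/kg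

Compound 3 cannot be told apart from compound 2, as a 1.5-fold higher number from compound 2 to compound 3 (0.19 log units; within the scatter) shows. Compound 4 `CN(C(=O)CNC(=O)CN1CCN(c2ccccc2)CC1)c1ccc(Cl)cc1C(=O)c1ccccc1Cl` carries 4-phenylpiperazin-1-yl in place of ethyl on a saturated chain carbon bound to a carbonyl carbon. The closest evidence is the reverse kind of exchange, with piperidin-1-yl leaving: an at least 2.7-fold lower number from compound 1 to compound 2 (0.44 log units; beyond the scatter), and an at least 1.8-fold lower number from compound 1 to compound 3 (0.25 log units; that floor lies within the scatter). Both rest on a limit, and neither involves the group entering here. A rise in this assay is therefore expected, modest in size and possibly ending at a limit, estimated as a 2.2-fold higher number from compound 3 to compound 4 (0.34 log units; beyond the scatter). For compound 4 the estimated value is 120 mg/kg, with an expected range from 50 mg/kg to 300 mg/kg.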

Compound 4, dose for half-maximal effect: > 100 mg/kg
Compound 4: a limit, no number; the forecaster's own chance of this, stated with the estimate: 50%; the middle value lies beyond the limit too.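

With 4-phenylpiperazin-1-yl on this saturated chain carbon bound to a carbonyl carbon, compound 4 gives only a limit, not a number, in this assay. The exchange reads as an at least 1.8-fold higher number from compound 3 to compound 4 (0.25 log units; that floor lies within the scatter), and as an at least 2.7-fold higher number from compound 2 to compound 4 (0.44 log units; beyond the scatter). A second ring-bearing group therefore joins piperidin-1-yl at the same ceiling, the only ceiling values among the compounds shown: the limit of > 100 mg/kg in this assay, at which 2 of the 4 values shown sit.

The step between compound 1 and compound 4 cannot be read, so these two groups cannot be ranked. Going by these compounds, whether a dimethylamino group or a morpholin-4-yl ring at this place would give a measurable number remains open.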